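A few compounds are considered here, and "the series" means these few. Any claim that something is new, unique, unknown or untested is made for them only; others in the source may bear on it.

- compound 1 `CC(C)CN(Cc1ccc(N2CCN(NS(C)(=O)=O)CC2)cc1)S(=O)(=O)Cc1ccccc1` in a physicochemical assay for solubility, in phosphate buffer, measured as kinetic solubility, with a stated time of 24 h, at pH 7.4 (a lower number here means a less soluble compound, a higher number a more soluble compound), gives <= 1000 nM, a limit
- compound 2 `CC(C)CN(Cc1ccc(N2CCN(CS(C)(=O)=O)CC2)cc1)S(=O)(=O)Cc1ccccc1` gives <= 1000 nM, a limit
- compound 3 `CC(C)CN(Cc1ccc(N2CCC(O)CC2)cc1)S(=O)(=O)Cc1ccccc1` gives 7000 nM

Compound 2 has only a limit, the one described by the limit of <= 1000 nM in this assay, at which 2 of the 3 values shown sit. Compound 4 `CC(=O)N1CCN(c2ccc(CN(CC(C)C)S(=O)(=O)Cc3ccccc3)cc2)CC1` differs from it by acetyl in place of (methylsulfonyl)methyl on an amine nitrogen in a ring, with acetyl in place of (methylsulfonyl)methyl on an amine nitrogen in a ring. Going by the values given here, the one step at this place, a step that the two limits leave unreadable from compound 1 to compound 2, gives no size. The readable steps, an at least 7.0-fold higher number from compound 1 to compound 3 (0.84 log units; beyond the scatter) and an at least 7.0-fold higher number from compound 2 to compound 3 (0.84 log units; beyond the scatter), each exchange the whole group on the aromatic carbon, so they offer only weak guidance here. In this assay, only a small upward step is expected, with no clear move beyond the scatter: an at least 1.5-fold higher number from compound 2 to compound 4 (0.17 log units; that floor lies within the scatter). Compound 4 is estimated at 1500 nM, with an expected range from 400 nM to 6000 nM.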

Compound 4, solubility: <= 1000 nM
Compound 4: no number, only a limit; the forecaster's own chance of this, stated with the estimate: 45%; at least 1.5-fold (0.17 log units) between middle value and limit.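

In this assay compound 4 gives <= 1000 nM, a limit. With acetyl on the amine nitrogen in a ring, the steps from the other two substituents at this nitrogen cannot be read, so no difference among the three is visible. The one readable step, an at least 7.0-fold lower number from compound 3 to compound 4 (0.84 log units; beyond the scatter), exchanges the whole group on the aromatic carbon, and a third substituent at this nitrogen now sits at the shared limit: the limit of <= 1000 nM in this assay, at which 3 of the 4 values shown sit.

Going by these compounds, how far the three limited compounds differ remains open. Also open, on these data alone, is whether an amine or a carboxylic acid on a short chain at this nitrogen would give a measurable number.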